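Carboxy in place of an amide chain on the shared core

The source may hold more compounds than are shown below. What is called first, only, known or untested is meant among the compounds shown, and "the series" means these compounds.

The compounds here share one core and differ in the group carried by a five-membered aromatic ring. For the measured compounds named here, compound 1 `CCNC(=O)c1noc(-c2cc(C(C)C)c(O)cc2O)c1-c1cc(CNC(C)C)no1` is the only one with a number: in a functional assay on A2780 cells (Homo sapiens) for inhibition (on this read-out lower numbers stand for stronger inhibition and higher numbers for weaker inhibition), compound 1 gives 38 nM. Compound 2 `CCNC(=O)c1noc(-c2cc(C(C)C)c(O)cc2O)c1-c1cc(CNC(=O)CC)no1` carries a (propanoylamino)methyl group, and in this assay compound 2 gives "not determined" (no result reported), so no result was reported for it. Compound 3 `CCCN(CCC)Cc1cc(-c2c(C(=O)NCC)noc2-c2cc(C(C)C)c(O)cc2O)on1` likewise gives "not determined" (no result reported) in this assay, so no result was reported for it either. So compound 2 stands without a number, and one further compound stands with it in that position.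

The step to compound 4 `CCNC(=O)c1noc(-c2cc(C(C)C)c(O)cc2O)c1-c1cc(C(=O)O)no1` is carboxy in place of (propanoylamino)methyl on an aromatic carbon. Going by the values given here, since compound 2 has no value, the size of this step cannot be read from a measured pair, and no step between two measured compounds exists at all in this set. The expectation for compound 4 therefore rests on compound 1 with its 38 nM, and a weaker result than that is expected, beyond the scatter. Compound 4 is estimated at 600 nM, within 100 nM to 5000 nM.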

Compound 4, half-maximal inhibitory concentration: 20000 nM
Compound 4: middle estimate off by 33-fold (1.52 log units), on the low side, and the stated range ends below it.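

In this assay the exchange of (isopropylamino)methyl for carboxy gives a 530-fold higher number from compound 1 to compound 4 (2.72 log units; beyond the scatter) and so turns a strong inhibitor into a very weak one. For the compounds shown here, this is the first step in the set that can be read, and it shows that the group on this aromatic carbon, next to the ring nitrogen, matters greatly for inhibition. Nothing at hand explains the size of this drop, so the result records how much changed and not why.

Going by these compounds alone, compound 2 and compound 3 have no number, so no step involving them can be read. From the compounds shown here alone, it stays open whether the drop belongs to carboxy itself or to the absence of the amine, and a methyl ester or a simple aminomethyl group at this position would be the kind of group to separate the two.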